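Fluorine on the aniline ring of two pyridopyrimidinone amides

This account rests on a few compounds, and the source may have more. Where it says the series, first, only, none or still open, it means among the compounds named here.

The study centres on a pair of related cores. Compound 1, `O=C(Nc1ccc(Oc2ccnc3[nH]ccc23)cc1)c1cc2cccnc2n(-c2ccc(F)cc2)c1=O`, gives 1360 nM in a functional assay on U-87MG ATCC cells for antiproliferative activity against U-87 MG (Homo sapiens), read by MTT assay, with a stated time of 72 h; on this read-out lower numbers stand for stronger inhibition and higher numbers for weaker inhibition. Compound 2, `O=C(Nc1ccc(Oc2ccnc3[nH]ccc23)c(F)c1)c1cc2cccnc2n(-c2ccc(F)cc2)c1=O`, carries one alteration, (fluoro in place of hydrogen on an aromatic carbon), and in this assay compound 2 gives 620 nM. That step, a 2.2-fold lower number from compound 1 to compound 2 (0.34 log units; beyond the scatter), is modest but beyond the scatter of repeated runs.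

Compound 3, `Cn1ccc2c(Oc3ccc(NC(=O)c4cc5cccnc5n(-c5ccccc5)c4=O)cc3)ccnc21`, has a different core; the difference between the two cores is not broken down here. In this assay compound 3 gives 5030 nM, the highest of the three numbers, and its steps to compound 1 and compound 2 both lie beyond the scatter.

Compound 4, `Cn1ccc2c(Oc3ccc(NC(=O)c4cc5cccnc5n(-c5ccccc5)c4=O)cc3F)ccnc21`, has not yet been measured. It differs from compound 3 by fluoro in place of hydrogen on an aromatic carbon, the same change that separates compound 2 from compound 1, and at the same place on the ring. Among the compounds with values here, for compound 4 the expected step is a 2.1-fold lower number from compound 3 to compound 4 (0.32 log units; beyond the scatter), a size that rests on the one measured example of this change, the step of a 2.2-fold lower number from compound 1 to compound 2 (0.34 log units; beyond the scatter). As far as these compounds go, whether the second core carries the change in the same way is unknown, so the expectation is held loosely. On that basis compound 4 is estimated at 2400 nM in this assay, with a range expected from 1100 nM to 5500 nM.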

Compound 4, half-maximal inhibitory concentration: 3590 nM
Estimate against measurement, compound 4: 1.5-fold (0.17 log units) below; measured number inside the range.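

On the second core, in this assay, fluoro in place of hydrogen on an aromatic carbon gives a 1.4-fold lower number from compound 3 to compound 4 (0.15 log units; within the scatter), a step too small to separate the two compounds, whereas the same change on the first core lies beyond the scatter. Set side by side, the two steps cannot be told apart: the same change on two cores in this assay, a 2.2-fold lower number (0.34 log units; beyond the scatter) from compound 1 to compound 2 and a 1.4-fold lower number (0.15 log units; within the scatter) from compound 3 to compound 4, 1.6-fold (0.19 log units) apart, within the scatter of two such steps This shows that the results fit a change of similar size on both cores, but it does not show that the change carries over reliably, since the comparison rests on only two pairs, and on the second core the step itself cannot be distinguished from the scatter of repeated measurements.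

The compounds shown leave open whether a chloro, methyl or methoxy group at this same place on the ring, ortho to one large group and meta to the other, would give a step that stands clear of the scatter on both cores. They also leave open whether fluoro in place of hydrogen would behave the same way on a third core, or whether an amine or a carboxylic acid at this place would do so.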